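The compounds below may be only part of what the source reports. "The series", "measured", "known", "first", "only" and "open" are said of these compounds alone.

Two measured compounds share one core and differ only in the aromatic ring attached to a sulfonamide nitrogen. Compound 1 `C=C1CC[C@@H]2[C@](C)(COC(C)=O)[C@H](OC(C)=O)CC[C@@]2(C)[C@H]1CC(Nc1ccc(S(=O)(=O)Nc2ccc(Cl)nn2)cc1)C1=CCOC1=O` carries a 6-chloropyridazin-3-yl there, and in a functional assay on PC-3 cells (Homo sapiens) for inhibition, read by sulforhodamine B assay, with a stated time of 48 h (on this read-out lower numbers stand for higher toxicity in this test and higher numbers for lower toxicity in this test), compound 1 gives 15800 nM. Compound 2 `C=C1CC[C@@H]2[C@](C)(COC(C)=O)[C@H](OC(C)=O)CC[C@@]2(C)[C@H]1CC(Nc1ccc(S(=O)(=O)Nc2ncccn2)cc1)C1=CCOC1=O` carries a pyrimidin-2-yl instead, and in this assay compound 2 gives 17500 nM. The step of a 1.1-fold higher number from compound 1 to compound 2 (0.04 log units; within the scatter) is within the scatter, so compound 2 stands alongside compound 1 rather than apart from it.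

Compound 3 `C=C1CC[C@@H]2[C@](C)(COC(C)=O)[C@H](OC(C)=O)CC[C@@]2(C)[C@H]1CC(Nc1ccc(S(=O)(=O)Nc2nccs2)cc1)C1=CCOC1=O` continues this series with 1,3-thiazol-2-yl in place of pyrimidin-2-yl on a sulfonamide nitrogen. Within the data shown here, the only measured step that bears on such a swap of the ring on the sulfonamide nitrogen is a 1.1-fold higher number from compound 1 to compound 2 (0.04 log units; within the scatter), which did not move the number beyond the scatter. No step beyond the scatter is therefore expected in this assay for compound 3. Compound 3 is expected to give 17000 nM, with a range from 8000 nM to 36000 nM. This expectation corresponds to a 1.0-fold lower number from compound 2 to compound 3 (0.01 log units; within the scatter).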

Compound 3, concentration lethal to 50% of the cells: 52200 nM
Beside the measured number, compound 3's estimate is 3.1-fold (0.49 log units) below it; the measured number lies above the stated range.
By their numbers in this assay, from the lowest: compounds 1 and 2 (each within the scatter of the next); then compound 3.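

The ring on the sulfonamide nitrogen can shift the number after all: in this assay, 1,3-thiazol-2-yl in place of pyrimidin-2-yl gives a 3.0-fold higher number from compound 2 to compound 3 (0.47 log units; beyond the scatter) and, in place of 6-chloropyridazin-3-yl, gives a 3.3-fold higher number from compound 1 to compound 3 (0.52 log units; beyond the scatter). Compound 1 and compound 2 alone suggested a position indifferent to this swap, whereas compound 3 stands apart from both, with lower toxicity in this test. Nothing presented here explains why the number rises.

Because the ring that enters differs from the others in both ring size and its sulfur atom, these compounds cannot show which of the two matters. An oxazol-2-yl ring, with oxygen in place of the sulfur, or a plain phenyl ring would extend the comparison at this position.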